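The compounds below may be only part of what the source reports. "The series", "measured", "known", "first", "only" and "open" are said of these compounds alone.

Measured compounds:
- compound 1, `COc1cc(/C(Cl)=C/C=C(\C#N)C(=O)c2c[nH]c3ccccc23)cc(OC)c1OC`: an ADME assay on Vero cells (Chlorocebus sabaeus) for cytotoxicity, read by sulforhodamine B assay, with a stated time of 48 h (a higher number here means that more compound is tolerated, a lower number that less compound is tolerated), 54200 nM
- compound 2, `COc1ccc(/C(Cl)=C/C=C(\C#N)C(=O)c2c(C)[nH]c3ccccc23)cc1`: compound 2 gives "not determined" (no result reported)
- compound 3, `COc1ccc(/C(Cl)=C/C=C(\C#N)C(=O)c2c[nH]c3ccccc23)cc1OC`: compound 3 gives "not determined" (no result reported)

Compound 3 therefore stands without any number in this assay, and compound 2 is a second entry without a number, so only compound 1 supplies a measured value here. Compound 4, `COc1ccc(/C(Cl)=C/C=C(\C#N)C(=O)c2c(C)[nH]c3ccccc23)cc1OC`, differs from compound 3 by a single small change: methyl in place of hydrogen on an aromatic carbon. Within the data shown here, no measured pair shows what such a change does in this assay. A change of one carbon is expected to move the cytotoxicity reading little, if at all, with no clear direction and nothing beyond the usual scatter. Compound 4 is estimated at 50000 nM, with a range from 20000 nM to 150000 nM.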

Compound 4, concentration lethal to 50% of the cells: 65900 nM
For compound 4 the middle estimate is 1.3-fold (0.12 log units) below the measured one; the range from low to high includes it.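

Among these compounds, no step from compound 3 to compound 4 can be read, as compound 3 has no single number to set against compound 4. Going by these compounds, what methyl in place of hydrogen on an aromatic carbon does here stays open, and no supporting evidence bears on the result.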